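The compounds below may be only part of what the source reports. "The series", "measured", "known", "first", "only" and "open" are said of these compounds alone.

Measured compounds in the series:
- compound 1, `CNC[C@@H]1CCN(c2cc3c(cc2F)c(=O)c(C(=O)O)cn3Cc2ccc(-n3cccn3)cc2)C1`
- compound 2, `O=C(O)c1cn(Cc2ccc(-n3cccn3)cc2)c2cc(NC[C@H]3CCNC3)c(F)cc2c1=O`
- compound 3, `O=C(O)c1cn(Cc2ccc(-c3ccccc3)cc2)c2cc(NC[C@H]3CCNC3)c(F)cc2c1=O`

In an assay on isolated protein for inhibition of DNA topoisomerase 1 (Homo sapiens), with a stated time of 15 min (on this read-out lower numbers stand for stronger inhibition and higher numbers for weaker inhibition), compound 1 reaches only a limit of the assay, > 200000 nM. In this assay compound 2 gives 187000 nM. In this assay compound 3 gives 100000 nM. Compound 2 thus sits among the two numbered values with compound 3 nearest, and the step of a 1.9-fold lower number from compound 2 to compound 3 (0.27 log units; within the scatter) sits within the scatter, while compound 1 sits at the limit of > 200000 nM in this assay, at which 1 of the 3 values shown sits.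

The next compound, compound 4, `O=C(O)c1cn(Cc2ccc(-n3cccn3)cc2)c2cc(N3CC4CNCC4C3)c(F)cc2c1=O`, differs from compound 2 by a group of 8 heavy atoms (6 carbon, 2 nitrogen; 2 five-membered non-aromatic rings with 1 hetero atom each) in place of a group of 7 heavy atoms (5 carbon, 2 nitrogen; one five-membered non-aromatic ring with 1 hetero atom), on an aromatic carbon, ortho to a fluoro group. Going by the values given here, the step that bears on this position is the one from compound 1 to compound 2, which also exchanges the amine-bearing group on that carbon: an at least 1.0-fold lower number from compound 1 to compound 2 (0.02 log units; that floor lies within the scatter), with compound 1 at a limit. The step of a 1.9-fold lower number from compound 2 to compound 3 (0.27 log units; within the scatter) concerns a different position and gives no lead here. Among the compounds with values here, nothing among the measured compounds shows a change at this carbon that moves the number beyond the scatter, and the nearest analogue with a ring nitrogen on that carbon, compound 1, sits at a limit.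

Compound 4 is therefore expected to give about 200000 nM, within 80000 nM to 500000 nM, with a fair chance of only a limit. The estimated step of a 1.1-fold higher number from compound 2 to compound 4 (0.03 log units; within the scatter) from compound 2 to compound 4 is expected to stay within the scatter.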

Compound 4, half-maximal inhibitory concentration: 173000 nM
The estimate for compound 4 lay 1.2-fold (0.06 log units) above the measured number; measured number inside the range.
By their numbers in this assay, from the lowest: compounds 3, 4 and 2 (each within the scatter of the next). At a limit, above all of these: compound 1.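

Replacing ((pyrrolidin-3-yl)methyl)amino on this aromatic carbon, ortho to a fluoro group, with the group of two five-membered non-aromatic rings gives a 1.1-fold lower number from compound 2 to compound 4 (0.03 log units; within the scatter) in this assay. Unlike the earlier step at this carbon, this comparison is read between two numbers, and it shows that the added ring and the loss of the defined stereocentre leave the read-out within the scatter for this pair. The step of an at least 1.1-fold lower number from compound 1 to compound 4 (0.06 log units; that floor lies within the scatter) is only a floor, since one end of it is a limit of the assay: the limit of > 200000 nM in this assay, at which 1 of the 4 values shown sits.

The numbered values shown all lie within the scatter of the next, so they do not show whether any group on this carbon can move the number beyond the scatter in this assay. Open, on these data alone, are other amines at this place, such as a piperazine or an open-chain aminoethylamino group, and whether phenyl in place of 1H-pyrazol-1-yl would read the same when paired with the group of compound 4.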